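From 4-methylphenyl to 2,4-difluorophenyl: a clearance forecast

The compounds below may be only part of what the source reports. "The series", "measured", "known", "first", "only" and "open" are said of these compounds alone.

compound 1, `Cc1ccc(NC(=O)[C@H]2CN(C)C[C@@H]2c2ccc(/C=C/C(=O)Nc3ccccc3N)cc2)cc1`: 62 mL/min/kg
compound 2, `CN1C[C@H](C(=O)Nc2ccc(C(F)(F)F)cc2)[C@@H](c2ccc(/C=C/C(=O)Nc3ccccc3N)cc2)C1`: 23 mL/min/kg
compound 3, `CN1C[C@H](C(=O)Nc2ccc(Cl)c(Cl)c2)[C@@H](c2ccc(/C=C/C(=O)Nc3ccccc3N)cc2)C1`: 36 mL/min/kg

These three compounds share one core and were measured in an in vitro ADME assay on microsomes from liver (Mus musculus) for pharmacokinetics, read by LC-MS, with a stated time of 10 min, tested at 1 uM; a lower number here means slower removal, a higher number faster removal of the compound. Compound 1 gives the highest of the three numbers in this assay; its nearest neighbour is compound 3 (a 1.7-fold lower number from compound 1 to compound 3 (0.24 log units; within the scatter)), and the furthest is compound 2 (a 2.7-fold lower number from compound 1 to compound 2 (0.43 log units; beyond the scatter)). Compound 4, `CN1C[C@H](C(=O)Nc2ccc(F)cc2F)[C@@H](c2ccc(/C=C/C(=O)Nc3ccccc3N)cc2)C1`, has not yet been measured. It differs from compound 1 in one place: 2,4-difluorophenyl in place of 4-methylphenyl on an amide-type nitrogen. Among the compounds with values here, two measured steps bear on this change, since each of them also replaces the 4-methylphenyl on the amide-type nitrogen: a 2.7-fold lower number from compound 1 to compound 2 (0.43 log units; beyond the scatter) and a 1.7-fold lower number from compound 1 to compound 3 (0.24 log units; within the scatter). Both point downward, one beyond the scatter and one within it. A downward step of similar size is therefore expected for compound 4, estimated as a 1.8-fold lower number from compound 1 to compound 4 (0.25 log units; within the scatter), though it could still land within the scatter. Compound 4 is expected to give 35 mL/min/kg in this assay, with a range from 18 mL/min/kg to 70 mL/min/kg.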

Compound 4, clearance: 27 mL/min/kg
Beside the measured number, compound 4's estimate is 1.3-fold (0.11 log units) above it; measured number inside the range.
By their numbers in this assay, from the lowest: compounds 2, 4, 3 and 1 (each within the scatter of the next, the first and the last beyond it).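

In this assay, the 2,4-difluorophenyl is a third replacement for the 4-methylphenyl on the amide-type nitrogen to give a lower number (a 2.3-fold lower number from compound 1 to compound 4 (0.36 log units; beyond the scatter)), and this step lies beyond the scatter with fluorine as the only added element, whereas the step to compound 3 stayed within it. The replacements themselves cannot be told apart, as both remaining comparisons lie within the scatter (a 1.3-fold lower number from compound 3 to compound 4 (0.12 log units; within the scatter)) and (a 1.2-fold higher number from compound 2 to compound 4 (0.07 log units; within the scatter)), even though the rings carry different groups. No measurement available here gives a reason for any of these steps.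

The compounds shown leave open whether a ring carrying a methoxy group or a carboxylic acid would also give a lower number than compound 1. They also leave open whether a single fluorine, as in 4-fluorophenyl, would match the two in compound 4.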